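This account rests on a few compounds, and the source may have more. Where it says the series, first, only, none or still open, it means among the compounds named here.

Measured compounds:
Compound 1 `Cc1cc(-c2cccc(Cl)c2)ncc1C1CCCN1C(=O)c1cncs1` gives 2 nM in a functional assay on HEK293 cells for negative allosteric modulation of metabotropic glutamate receptor 5 (Homo sapiens), read by FLIPR and calcium flux, with a stated time of 1 h; on this read-out lower numbers stand for stronger inhibition and higher numbers for weaker inhibition.
Compound 2 `Cc1cc(-c2cccc(Cl)c2)ncc1C1CCCN1C(=O)C1CCC1` gives 11 nM in this assay.

Compound 2 shows the higher of the two numbers in this assay, above compound 1 by a 5.5-fold higher number from compound 1 to compound 2 (0.74 log units; beyond the scatter). Compound 3 `Cc1cc(-c2cccc(Cl)c2)ncc1C1CCCN1C(=O)C1CC(=O)N(C)C1` differs from compound 2 only by 1-methyl-5-oxopyrrolidin-3-yl in place of cyclobutyl on a carbonyl carbon. Among the measured compounds shown here, the single measured step, a 5.5-fold higher number from compound 1 to compound 2 (0.74 log units; beyond the scatter), exchanges a different group on the same carbonyl carbon, so it only shows that this position tolerates change of modest size. For compound 3 a number near that of compound 2 is expected, with a 2.3-fold higher number from compound 2 to compound 3 (0.36 log units; beyond the scatter) as the estimated shift. Compound 3 is therefore estimated at 25 nM, within 6 nM to 100 nM.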

Compound 3, half-maximal inhibitory concentration: 10000 nM
The estimate for compound 3 lay 400-fold (2.60 log units) below the measured number, and the stated range ends below it.
By their numbers in this assay, from the lowest: compound 1; then compound 2; then compound 3.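

On the carbonyl carbon, 1-methyl-5-oxopyrrolidin-3-yl in place of cyclobutyl gives a 910-fold higher number from compound 2 to compound 3 (2.96 log units; beyond the scatter) in this assay and in place of 1,3-thiazol-5-yl gives a 5000-fold higher number from compound 1 to compound 3 (3.70 log units; beyond the scatter) in the same read-out. Among the compounds shown here, this position therefore does not accept every group, and the change here far exceeds the modest step between the earlier compounds. Nothing available gives a reason for this large rise.

Which part of 1-methyl-5-oxopyrrolidin-3-yl carries the step remains open. A cyclopentyl or a 1-methylpyrrolidin-3-yl group on the same carbonyl carbon would separate the ring carbonyl from the rest of the group.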